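Fluorine position on the amide-bound phenyl of compound 2

The compounds below may be only part of what the source reports. "The series", "measured", "known", "first", "only" and "open" are said of these compounds alone.

compound 1 `CN(C)C(=O)c1cc2cnc(Nc3ccc(N)cn3)nc2n1C1CCCC1`: 62%
compound 2 `CN(C)C(=O)c1cc2cnc(Nc3ccc(NC(=O)C4(C(=O)Nc5cccc(F)c5)CC4)cc3)nc2n1C1CCCC1`: 98.8%

In a functional assay on NCI-H460 cells (Homo sapiens) for inhibition, read by CCK-8 assay, with a stated time of 72 h, tested at 10 uM (a higher number here means more inhibition of growth at the concentration tested, a lower number less inhibition of growth), compound 2 stands highest of the two measured compounds at 98.8%. Compound 1 gives 62%. The gap between these two compounds lies beyond the scatter. Compound 3 `CN(C)C(=O)c1cc2cnc(Nc3ccc(NC(=O)C4(C(=O)Nc5ccccc5F)CC4)cc3)nc2n1C1CCCC1` carries 2-fluorophenyl in place of 3-fluorophenyl on an amide-type nitrogen. Among the measured compounds shown here, no measured pair shows the effect of this change. A small fall in this assay, or none beyond the scatter, is expected. The expected step is a number 4.8 percentage points lower from compound 2 to compound 3 (within the scatter). The estimate for compound 3 is 94%, within a range of 80% to 102%.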

Compound 3, percent growth inhibition at one concentration: 93.1%
Beside the measured number, compound 3's estimate is 0.9 percentage points above it, within the range that was stated.
By their numbers in this assay, from the lowest: compound 1; then compounds 3 and 2 (each within the scatter of the next).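

In this assay, 2-fluorophenyl in place of 3-fluorophenyl on the amide-type nitrogen gives a number 5.7 percentage points lower from compound 2 to compound 3 (within the scatter). Among the compounds shown here, this is the first comparison that changes only one place, and at the single concentration tested the read-out does not separate these two fluorine positions. No measurement available here bears on the reason for this result.

Still open, as far as these compounds go, is whether unsubstituted phenyl, a chlorophenyl or a pyridyl ring on this nitrogen would read differently. Also open, from the compounds shown here alone, is whether compound 2 and compound 3 would separate at lower concentrations.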